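From Isopropyl to Cyclopentyl on the Amide Nitrogen

The source may hold more compounds than are shown below. What is called first, only, known or untested is meant among the compounds shown, and "the series" means these compounds.

Measured in an in vitro ADME assay on microsomes from liver (Mus musculus) for pharmacokinetics, read by LC-MS, with a stated time of 10 min, tested at 1 uM; a lower number here means slower removal, a higher number faster removal of the compound:
- compound 1 `CN1C[C@H](C(=O)Nc2cccc(Cl)c2)[C@@H](c2ccc(/C=C/C(=O)Nc3ccccc3N)cc2)C1`: 58 mL/min/kg
- compound 2 `Cc1cccc(NC(=O)[C@H]2CN(C)C[C@@H]2c2ccc(/C=C/C(=O)Nc3ccccc3N)cc2)c1`: 74 mL/min/kg
- compound 3 `CC(C)NC(=O)[C@H]1CN(C)C[C@@H]1c1ccc(/C=C/C(=O)Nc2ccccc2N)cc1`: 12 mL/min/kg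

Compound 3 has the lowest number of the three. Compound 4 `CN1C[C@H](C(=O)NC2CCCC2)[C@@H](c2ccc(/C=C/C(=O)Nc3ccccc3N)cc2)C1` differs from it in one place, with cyclopentyl in place of isopropyl on an amide-type nitrogen. Two measured steps change that same nitrogen, and both lie beyond the scatter: a 4.8-fold lower number from compound 1 to compound 3 (0.68 log units; beyond the scatter) and a 6.2-fold lower number from compound 2 to compound 3 (0.79 log units; beyond the scatter). Both replace an aromatic group with isopropyl. No non-aromatic ring has been measured there, so a modest rise in this assay, smaller than those steps, is expected. The expected change is a 2.0-fold higher number from compound 3 to compound 4 (0.30 log units; within the scatter). The estimate for compound 4 is 24 mL/min/kg, with an expected range of 12 mL/min/kg to 50 mL/min/kg.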

Compound 4, clearance: 61 mL/min/kg
Beside the measured number, compound 4's estimate is 2.5-fold (0.41 log units) below it; the measured number lies above the stated range.
By their numbers in this assay, from the lowest: compound 3; then compounds 1, 4 and 2 (each within the scatter of the next).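

In this assay cyclopentyl on this amide-type nitrogen gives a 5.1-fold higher number from compound 3 to compound 4 (0.71 log units; beyond the scatter), so the low number of compound 3 does not carry over to this non-aromatic ring. The result also sits level with both aromatic groups, as a 1.2-fold lower number from compound 2 to compound 4 (0.08 log units; within the scatter) and a 1.1-fold higher number from compound 1 to compound 4 (0.02 log units; within the scatter) show, so among these compounds an aromatic ring is not needed for a high number. No measured finding here accounts for the size of this rise.

Still open, on these data alone, is whether the low number belongs to isopropyl alone or extends to ethyl, tert-butyl or cyclopropyl. A chain ending in an amine on this nitrogen also remains an open case.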